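The source may report more compounds than this note shows. Statements on the series, on what has been measured and on what is new or still open speak of the compounds shown alone.

Compound 1 `Cc1ncc(COCc2ccccc2)c(/C=C/Cl)c1OCc1ccccc1`: 3 uM
Compound 2 `C#Cc1c(CO)cnc(C)c1O`: 8 uM

In an assay on TA3 cells for inhibition of pyridoxine-5'-phosphate oxidase (Mus musculus) (a higher number here means a weaker inhibitor, a lower number a stronger inhibitor), compound 2 gives the higher of the two numbers, 8 uM; compound 1 sits at 3 uM, a gap beyond the scatter. Compound 3 `C=C(Cl)c1c(CO)cnc(C)c1O` has not been measured. It differs from compound 2 by 1-chloroethenyl in place of ethynyl on an aromatic carbon. Going by the values given here, no measured pair isolates this change, and compound 1 carries too many other differences to serve as a guide. The expected step of a 1.3-fold lower number from compound 2 to compound 3 (0.12 log units; within the scatter) is therefore small, not beyond the scatter, in either direction. Compound 3 is estimated at 6 uM, within a range from 2 uM to 18 uM.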

Compound 3, concentration for 50% inhibition: 9.5 uM
Compound 3: middle estimate off by 1.6-fold (0.20 log units), on the low side; the range from low to high includes it.
By their numbers in this assay, from the lowest: compound 1; then compounds 2 and 3 (each within the scatter of the next).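

In this assay, 1-chloroethenyl in place of ethynyl on the aromatic carbon opposite the ring nitrogen gives (a 1.2-fold higher number from compound 2 to compound 3 (0.07 log units; within the scatter)). Going by these compounds alone, this is the first matched change at this position, and it shows that the swap from ethynyl to 1-chloroethenyl, with one more heavy atom, does not separate compound 2 from compound 3 in this read-out. Nothing available accounts for this match. Open, as far as these compounds go, is whether an amine, a carboxylic acid or a longer alkyl chain on this carbon would also read within the scatter of compound 2.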